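The compounds below may be only part of what the source reports. "The series", "measured", "known", "first", "only" and "open" are said of these compounds alone.

Of the compounds shown here, three of one shared core have been tested in a functional assay on NCI-H460 cells (Homo sapiens) for cytotoxicity, read by MTT assay, with a stated time of 72 h; a higher number here means a weaker inhibitor, a lower number a stronger inhibitor. Compound 1 `COc1cc2c(Oc3ccc(NC(=O)c4cn(-c5ccccc5C)nn4)cc3F)ccnc2cc1OCCCN1CCCCC1` gives 2100 nM. Compound 2 `COc1cc2c(Oc3ccc(NC(=O)c4cn(-c5ccccc5F)nn4)cc3F)ccnc2cc1OCCCN1CCCCC1` gives 210 nM, and compound 3 `COc1cc2c(Oc3ccc(NC(=O)c4cn(-c5ccc(Br)cc5)nn4)cc3F)ccnc2cc1OCCCN1CCCCC1` gives 360 nM. Among these three numbers compound 3 stands second highest: its gap to compound 2 lies within the scatter, while it differs from compound 1 by a 5.8-fold lower number from compound 1 to compound 3 (0.77 log units; beyond the scatter).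

Compound 4 `COc1cc2c(Oc3ccc(NC(=O)c4cn(-c5c(Cl)cccc5Cl)nn4)cc3F)ccnc2cc1OCCCN1CCCCC1` is the next compound. The change is 2,6-dichlorophenyl in place of 4-bromophenyl on an aromatic nitrogen, so the aryl group sitting on an aromatic nitrogen of a five-membered aromatic ring with 3 nitrogen is exchanged once more. Among the measured compounds shown here, two measured steps concern such an exchange: a 5.8-fold lower number from compound 1 to compound 3 (0.77 log units; beyond the scatter) and a 1.7-fold higher number from compound 2 to compound 3 (0.23 log units; within the scatter). A smaller change at that aryl group, a 10-fold lower number from compound 1 to compound 2 (1.00 log units; beyond the scatter), also shifted this assay noticeably. As far as these compounds go, these steps show that the aryl group on that nitrogen matters, but none of them carries a 2,6-dichlorophenyl, so the direction for compound 4 remains open. Compound 4 is therefore expected to give roughly 600 nM, within 180 nM to 2000 nM, meaning a step of a 1.7-fold higher number from compound 3 to compound 4 (0.22 log units; within the scatter) that may not exceed the scatter.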

Compound 4, half-maximal inhibitory concentration: 280 nM
Compound 4: middle estimate off by 2.1-fold (0.33 log units), on the high side; the range from low to high includes it.
By their numbers in this assay, from the lowest: compounds 2, 4 and 3 (each within the scatter of the next); then compound 1.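

In this assay, the 2,6-dichlorophenyl group gives a 1.3-fold lower number from compound 3 to compound 4 (0.11 log units; within the scatter) and a 1.3-fold higher number from compound 2 to compound 4 (0.12 log units; within the scatter), so on this aromatic nitrogen it cannot be told apart from 4-bromophenyl or 2-fluorophenyl. These three aryl groups carry different halogens, in different numbers and at different ring places, yet their values stay within the scatter of one another. Compound 1, with its 2-methylphenyl, is the one that stands apart, with a 7.5-fold lower number from compound 1 to compound 4 (0.88 log units; beyond the scatter).

Nothing measured here explains why the methyl-bearing ring differs from the three halogen-bearing rings. Still open, as far as these compounds go, is whether an aryl ring carrying an amine or a carboxylic acid, or a longer alkyl chain in place of the aryl ring, would stay at the level of compounds 2, 3 and 4 or fall towards compound 1.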